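The source may report more compounds than this note shows. Statements on the series, on what has been measured and on what is new or still open speak of the compounds shown alone.

In a functional assay on HCT-116 cells (Homo sapiens) for cytotoxicity, read by sulforhodamine B assay, with a stated time of 72 h (on this read-out lower numbers stand for stronger inhibition and higher numbers for weaker inhibition), compound 1 `C=C1C(=O)O[C@@H]2CC(C)=C([C@@H](C)CCCOC(C)=O)[C@@H](OC(=O)CN(CC)CC)[C@H]12` gives 13100 nM. Compound 2 `C=C1C(=O)O[C@@H]2CC(C)=C([C@@H](C)CCCOC(C)=O)[C@@H](OC(=O)CN3CCCCC3)[C@H]12` gives 13900 nM, so the two cannot be told apart: the step is a 1.1-fold higher number from compound 1 to compound 2 (0.03 log units; within the scatter). For the measured compounds named here, these are the only two numbers available, since the third compound reaches a limit of the assay. Compound 3 `C=C1C(=O)O[C@@H]2CC(C)=C([C@@H](C)CCCOC(C)=O)[C@@H](OC(=O)COc3ccc([N+](=O)[O-])cc3[N+](=O)[O-])[C@H]12` reads > 100000 nM, which is a limit and not a number.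

Compound 4 `C=C1C(=O)O[C@@H]2CC(C)=C([C@@H](C)CCCOC(C)=O)[C@@H](OC(=O)COc3ccc4c(CC)noc4c3)[C@H]12` differs from compound 1 by a group of 12 heavy atoms (9 carbon, 1 nitrogen, 2 oxygen; one five-membered aromatic ring with 2 hetero atoms, one six-membered aromatic ring of carbon only) in place of a group of 5 heavy atoms (4 carbon, 1 nitrogen; no ring), on a saturated chain carbon bound to a carbonyl carbon. The diethylamino group is therefore lost, and two fused-looking aromatic rings arrive in its place, joined to the same saturated chain carbon bound to a carbonyl carbon.

The step of a 1.1-fold higher number from compound 1 to compound 2 (0.03 log units; within the scatter) only exchanges one amine for another, so it says little about removing the amine altogether. Going by the values given here, compound 3 is the only measured compound without such an amine, and it is also the only one that gave no number. Among the compounds with values here, that is a single case, and its group is not the one in compound 4, so only a moderate move towards weaker inhibition is expected in this assay. The expected step is a 3.1-fold higher number from compound 1 to compound 4 (0.48 log units; beyond the scatter). For compound 4 the estimated value is 40000 nM, with an expected range from 13000 nM to 100000 nM.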

Compound 4, half-maximal inhibitory concentration: 18300 nM
Estimate against measurement, compound 4: 2.2-fold (0.34 log units) above; low and high end bracket the measured number.
By their numbers in this assay, from the lowest: compounds 1, 2 and 4 (each within the scatter of the next). At a limit, above all of these: compound 3.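

In this assay, the amine on the saturated chain carbon bound to a carbonyl carbon proves not to be required for a measurable number: with the new group of two aromatic rings in place of diethylamino the result is a 1.4-fold higher number from compound 1 to compound 4 (0.15 log units; within the scatter), and in place of piperidin-1-yl it is a 1.3-fold higher number from compound 2 to compound 4 (0.12 log units; within the scatter). Compound 3 also has no such amine, so the absence of the amine does not go with the loss of a number in every case, and exchanging the aromatic group on the oxygen on a saturated carbon gives an at least 5.4-fold lower number from compound 3 to compound 4 (0.73 log units; beyond the scatter). The reading of compound 3 is a limit and not a number, so that step has only a lower bound: the limit of > 100000 nM in this assay, at which 1 of the 4 values shown sits.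

Going by these compounds, whether a plain phenyl group on that oxygen, with no nitro groups, would read like compound 3 or like compound 4 stays open. The compounds shown also leave open what a morpholine or a carboxylic acid would give at the saturated chain carbon bound to a carbonyl carbon, and whether any group there can move the number beyond the scatter from that of compound 1.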